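Three Sulfur Substituents and a Fourth Awaited

The compounds below may be only part of what the source reports. "The series", "measured", "known", "first", "only" and "open" are said of these compounds alone.

Compound 1 `COc1ccc(-n2c(S)nnc2-c2cc(OC)c(OC)c(OC)c2)cc1` gives > 60000 nM (a limit)
Compound 2 `CCSc1nnc(-c2cc(OC)c(OC)c(OC)c2)n1-c1ccc(OC)cc1` gives 57700 nM
Compound 3 `COc1ccc(-n2c(SCc3ccc(F)cc3)nnc2-c2cc(OC)c(OC)c(OC)c2)cc1` gives 35000 nM

Within the data shown here, all three values come from a functional assay on PC-3 cells (Homo sapiens) for inhibition, read by MTT assay, with a stated time of 48 h (on this read-out lower numbers stand for stronger inhibition and higher numbers for weaker inhibition), and only two are actual numbers. Compound 3 holds one of these, and a 1.6-fold lower number from compound 2 to compound 3 (0.22 log units; within the scatter) does not set it apart from compound 2. Compound 4 `COc1ccc(C(=O)CSc2nnc(-c3cc(OC)c(OC)c(OC)c3)n2-c2ccc(OC)cc2)cc1` is not yet measured and carries (4-methoxyphenyl)carbonyl in place of 4-fluorophenyl on a saturated chain carbon bound to a sulfur as its one difference. Changes on the sulfur have so far given only an at least 1.0-fold lower number from compound 1 to compound 2 (0.01 log units; that floor lies within the scatter) and an at least 1.7-fold lower number from compound 1 to compound 3 (0.23 log units; that floor lies within the scatter) as well as the step above, so no step beyond the scatter is expected in this assay here. The estimated 1.2-fold lower number from compound 3 to compound 4 (0.07 log units; within the scatter) is expected to stay small. For compound 4 a value of 30000 nM is expected, with an estimated range from 11000 nM to 60000 nM in this read-out.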

Compound 4, half-maximal inhibitory concentration: > 60000 nM
Compound 4: no number, only a limit (the forecaster's own chance of this, stated with the estimate: 15%); middle value at least 2.0-fold (0.30 log units) away from the limit.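

In this assay, among these compounds, compound 4 gives only a limit and no number, the first group on the saturated chain carbon bound to a sulfur to do so: the limit of > 60000 nM in this assay, at which 2 of the 4 values shown sit. The change reads as an at least 1.7-fold higher number from compound 3 to compound 4 (0.23 log units; that floor lies within the scatter) and an at least 1.0-fold higher number from compound 2 to compound 4 (0.01 log units; that floor lies within the scatter), and both floors lie within the scatter, so it is not yet shown to exceed the earlier steps. The step between the two limits, from compound 1 to compound 4, cannot be read. Going by these compounds, how far compound 4 lies past its limit stays open, as does whether an amine or a carboxylic acid on that chain carbon would give a number.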